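The source may hold more compounds than are shown below. What is called first, only, known or untested is meant among the compounds shown, and "the series" means these compounds.

Working notes on the series. Compound 1 `O=S(=O)(/C=C/c1ccc(O)c(O)c1)CCCc1ccccc1` carries a phenyl group on the chain that runs from the sulfonyl sulfur. In a functional assay, read by fluorescence and spectrophotometry, with a stated time of 1 h (on this read-out lower numbers stand for an effect already at smaller amounts and higher numbers for an effect only at larger amounts of compound), compound 1 gives 11500 nM, the highest of the three numbers shown so far, though each of the other two lies within the scatter of it. Compound 2 `C=CCCCCCCS(=O)(=O)/C=C/c1ccc(O)c(O)c1` gives 6400 nM in this assay, and compound 3 `CCCCCS(=O)(=O)/C=C/c1ccc(O)c(O)c1` gives 8100 nM. The steps away from compound 1 are a 1.8-fold lower number from compound 1 to compound 2 (0.25 log units; within the scatter) and a 1.4-fold lower number from compound 1 to compound 3 (0.15 log units; within the scatter), and the step between the other two is a 1.3-fold higher number from compound 2 to compound 3 (0.10 log units; within the scatter).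

Compound 4 `O=S(=O)(/C=C/c1ccc(O)c(O)c1)CCCC1CCCC1` is not yet measured. It differs from compound 1 as follows: cyclopentyl in place of phenyl on a saturated chain carbon, three bonds along the chain from a sulfonyl sulfur. Among the compounds with values here, the steps that bear on this change are the two that replace the same phenyl by open chains at the same place, a 1.8-fold lower number from compound 1 to compound 2 (0.25 log units; within the scatter) and a 1.4-fold lower number from compound 1 to compound 3 (0.15 log units; within the scatter); neither left the scatter, and both sit at lower numbers. Within the data shown here, a saturated ring at this place has no precedent among the measured compounds, so the expectation rests on those two steps alone. For compound 4 in this assay a step of a 1.4-fold lower number from compound 1 to compound 4 (0.13 log units; within the scatter) is expected, leaning toward a lower number but not beyond the scatter. The estimate for compound 4 is therefore 8500 nM, with a range from 4000 nM to 18000 nM.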

Compound 4, half-maximal effective concentration: 6300 nM
For compound 4 the middle estimate is 1.3-fold (0.13 log units) above the measured one, and the stated range covers the measured number.
By their numbers in this assay, from the lowest: compounds 4, 2, 3 and 1 (each within the scatter of the next).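

In this assay, a saturated ring of carbon only now joins the open chains as a replacement for phenyl on a saturated chain carbon, three bonds along the chain from a sulfonyl sulfur, and it gives a 1.8-fold lower number from compound 1 to compound 4 (0.26 log units; within the scatter), so this change too stays inside the scatter. The ring is also not separated from the open chains, with a 1.3-fold lower number from compound 3 to compound 4 (0.11 log units; within the scatter) and a 1.0-fold lower number from compound 2 to compound 4 (0.01 log units; within the scatter), which means that phenyl, cyclopentyl, ethyl and pent-4-en-1-yl at this place are not told apart by this read-out, whether the group is aromatic, a non-aromatic ring or an open chain. No measurement at hand offers an explanation for this flat picture.

All the groups shown at this place are built of carbon only, so it remains open whether an amine, a carboxylic acid or a hydroxyl at the end of the chain would move the number beyond the scatter. Also open, from the compounds shown here alone, is whether cyclohexyl, or cyclopentyl carried on a longer chain, would do so, and whether the same flat picture would hold on a changed core.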